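Swapping a Dimethylamino for a Propylamino Group

This account rests on a few compounds, and the source may have more. Where it says the series, first, only, none or still open, it means among the compounds named here.

Of the compounds shown here, three have been measured in an assay on HeLa cells for binding affinity to Vasopressin V2 receptor (Homo sapiens); on this read-out higher numbers stand for weaker inhibition and lower numbers for stronger inhibition. Compound 1 `Cc1cc(N)ccc1C(=O)N1CCCCc2cc(Cl)ccc21` gives 4.1 nM. Compound 2 `CN(C)c1ccc(C(=O)N2CCCCc3ccccc32)c(Cl)c1` gives 18 nM, and compound 3 `CN(C)c1ccc(C(=O)N2CCCCc3cc(Cl)ccc32)c(Cl)c1` gives 13 nM. Compound 2 stands at the high end of these three numbers: its gap to compound 3 is within the scatter, while its gap to compound 1 lies beyond it.

Compound 4 `CCCNc1ccc(C(=O)N2CCCCc3ccccc32)c(Cl)c1` differs from compound 2 in one place: propylamino in place of dimethylamino on an aromatic carbon. Going by the values given here, none of the measured steps touches this amino group, so nothing among the data shows how this assay responds to the exchange of dimethylamino for propylamino. Among the compounds with values here, the single measured step, a 1.4-fold lower number from compound 2 to compound 3 (0.14 log units; within the scatter), concerns a chloro on the shared core and stayed within the scatter, and on that slim footing the step of a 1.2-fold lower number from compound 2 to compound 4 (0.08 log units; within the scatter) is expected to be small as well, with no clear direction. Compound 4 is therefore estimated at 15 nM, with a range from 5 nM to 45 nM.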

Compound 4, half-maximal inhibitory concentration: 18 nM
For compound 4 the middle estimate is 1.2-fold (0.08 log units) below the measured one, and the stated range covers the measured number.
By their numbers in this assay, from the lowest: compound 1; then compounds 3, 2 and 4 (each within the scatter of the next).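

In this assay, going by these compounds alone, the exchange at this amino group gives no change at the digits printed from compound 2 to compound 4 (within the scatter), the first measured step at this place on the shared core. Although the groups differ in their counts, with 4 heavy atoms against 3 and 1 hydrogen-bond donor against 0, this read-out does not separate them, so this place accepts either group in this pair. Nothing on hand explains why the number holds.

This single pair cannot tell the effect of chain length from that of the hydrogen on the nitrogen, since both differ at once. A plain amine, a butylamino or longer chain, or a carboxylic acid at this place could show how much variation this position accepts before the number moves beyond the scatter.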